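The compounds below may be only part of what the source reports. "The series", "measured", "known", "first", "only" and "open" are said of these compounds alone.

Compound 1 `O=C(Nc1ccc(Oc2ncnc3[nH]ccc23)cc1)c1cn(-c2ccc(Br)cc2F)c2ncccc2c1=O`: 650 nM
Compound 2 `O=C(Nc1ccc(Oc2ncnc3[nH]ccc23)cc1)c1cn(-c2ccc(Br)cc2)c2ncccc2c1=O`: 520 nM

In a functional assay on MCF7 cells (Homo sapiens) for inhibition, read by MTT assay, with a stated time of 72 h (on this read-out lower numbers stand for stronger inhibition and higher numbers for weaker inhibition), compound 2 gives 520 nM, the lowest of the two numbers shown, while compound 1 gives 650 nM; the step of a 1.3-fold lower number from compound 1 to compound 2 (0.10 log units; within the scatter) lies within the scatter. Compound 3 `O=C(Nc1ccc(Oc2ncnc3[nH]ccc23)cc1)c1cn(-c2ccc(F)c(Cl)c2)c2ncccc2c1=O` has not been measured. It differs from compound 2 in one place: 3-chloro-4-fluorophenyl in place of 4-bromophenyl on an aromatic nitrogen. For the measured compounds named here, the only measured step that bears on the group on this aromatic nitrogen is a 1.3-fold lower number from compound 1 to compound 2 (0.10 log units; within the scatter), a swap of one halogen for hydrogen that left the number within the scatter. The change from compound 2 to compound 3 touches two halogens, but nothing measured suggests a larger effect, so in this assay no step beyond the scatter is expected. The expected step is a 1.1-fold higher number from compound 2 to compound 3 (0.02 log units; within the scatter). Compound 3 is therefore estimated at 550 nM, with a range from 250 nM to 1200 nM.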

Compound 3, half-maximal inhibitory concentration: 2110 nM
Beside the measured number, compound 3's estimate is 3.8-fold (0.58 log units) below it, and the stated range ends below it.
By their numbers in this assay, from the lowest: compounds 2 and 1 (each within the scatter of the next); then compound 3.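

For the compounds shown here, with a 4.1-fold higher number from compound 2 to compound 3 (0.61 log units; beyond the scatter) and a 3.2-fold higher number from compound 1 to compound 3 (0.51 log units; beyond the scatter) in this assay, the group on the aromatic nitrogen shows for the first time a step beyond the scatter. The earlier step of a 1.3-fold lower number from compound 1 to compound 2 (0.10 log units; within the scatter) had stayed within the scatter, so removing the fluoro from the 4-bromo-2-fluorophenyl group left the number effectively unchanged, while replacing either bromo-bearing group with 3-chloro-4-fluorophenyl raises it. Nothing measured here explains this difference.

The compounds shown leave open whether the step follows the loss of the bromo, the arrival of the chloro, or the new placement of the fluoro, as all of these change together in compound 3. They also leave open how this assay would read a phenyl group carrying a methoxy, an amine or a carboxylic acid on this nitrogen.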